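The source may report more compounds than this note shows. Statements on the series, on what has been measured and on what is new or still open speak of the compounds shown alone.

Measured in an ADME assay on CHO cells (Cricetulus griseus) for cytotoxicity, read by MTT assay; a lower number here means that less compound is tolerated, a higher number that more compound is tolerated:
- compound 1 `C[C@@H]1CN(c2nccc3[nH]c(-c4ccc(F)c(F)c4)nc23)C[C@H](C)N1`: 6500 nM
- compound 2 `NC1CCN(c2nccc3[nH]c(-c4ccc(F)c(F)c4)nc23)CC1`: 8200 nM

Compound 2, at 8200 nM, stands level with compound 1, the two values lying within the scatter of each other. Compound 3 `CN1CCN(CC2CCN(c3nccc4[nH]c(-c5ccc(F)c(F)c5)nc34)CC2)CC1` is the next to be read. Its change from compound 2 is (4-methylpiperazin-1-yl)methyl in place of amino on a saturated ring carbon. Going by the values given here, only one measured step bears on this, a 1.3-fold higher number from compound 1 to compound 2 (0.10 log units; within the scatter), and it concerns a different change, so it is weak guidance. It offers no direction, so no step beyond the scatter is expected in this assay, although the entering group is larger than anything measured so far and the range must stay wide. The estimate is a 1.3-fold lower number from compound 2 to compound 3 (0.10 log units; within the scatter). For compound 3 the expected value is 6500 nM, with an estimated range of 2200 nM to 19000 nM.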

Compound 3, half-maximal cytotoxic concentration: 7400 nM
The estimate for compound 3 lay 1.1-fold (0.06 log units) below the measured number; measured number inside the range.
By their numbers in this assay, from the lowest: compounds 1, 3 and 2 (each within the scatter of the next).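

In this assay, the step is a 1.1-fold lower number from compound 2 to compound 3 (0.04 log units; within the scatter), so exchanging the single-atom amino group for the far larger (4-methylpiperazin-1-yl)methyl on this saturated ring carbon does not separate the two compounds. The earlier pair had shown only an exchange of the whole amine on the aromatic carbon; this step shows that, on the piperidine ring itself, adding a six-membered ring with 2 hetero atoms and losing the hydrogen-bond donor of amino leaves the number within the scatter. Nothing measured here gives a reason for this result.

As far as these compounds go, whether a carboxylic acid on that same ring carbon, or a longer chain between it and the 4-methylpiperazin-1-yl ring, would move the number beyond the scatter stays open. So does the effect of any change away from this position, since all three compounds keep the rest of the core unchanged.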